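Swapping Methyls for Chlorines on the Sulfonyl Ring

A few compounds are considered here, and "the series" means these few. Any claim that something is new, unique, unknown or untested is made for them only; others in the source may bear on it.

Of the compounds shown here, two have been measured in an ADME assay on microsomes from liver (Homo sapiens) for metabolic stability, tested at 2.5 uM; on this read-out lower numbers stand for slow clearance and higher numbers for fast clearance. Compound 1 `O=S(=O)(c1cc(Cl)cc(Cl)c1)c1cnc2cc(F)ccc2c1-c1ccc(Cl)cc1` gives 0.13 mL/min in this assay. Compound 2 `COc1ccc(-c2c(S(=O)(=O)c3ccc(C)c(C)c3)cnc3cc(F)ccc23)cc1` gives 4.13 mL/min in this assay, the higher of the two numbers, and its gap to compound 1 lies well beyond the scatter of repeated measurements. Compound 3 `COc1ccc(-c2c(S(=O)(=O)c3cc(Cl)cc(Cl)c3)cnc3cc(F)ccc23)cc1` has not yet been measured. It differs from compound 2 in a single place: 3,5-dichlorophenyl in place of 3,4-dimethylphenyl on a sulfonyl sulfur. Going by the values given here, the 3,5-dichlorophenyl that enters is the same group found on the sulfonyl sulfur of compound 1, although compound 1 also carries a different group elsewhere, so the two measured compounds differ in two places and no single step between them is known. In this assay the step expected is an 8.3-fold lower number from compound 2 to compound 3 (0.92 log units; beyond the scatter), a downward move beyond the scatter. This expectation rests on compound 1, which gives 0.13 mL/min while carrying the same 3,5-dichlorophenyl on its sulfonyl sulfur. Compound 3 is therefore estimated at 0.5 mL/min in this assay, with a range from 0.15 mL/min to 1.8 mL/min.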

Compound 3, intrinsic clearance in a liver preparation (reported as CLH), per the amount of preparation that the assay uses: 1 mL/min
The estimate for compound 3 lay 2.0-fold (0.30 log units) below the measured number, within the range that was stated.
By their numbers in this assay, from the lowest: compound 1; then compound 3; then compound 2.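

In this assay, putting 3,5-dichlorophenyl in place of 3,4-dimethylphenyl on a sulfonyl sulfur gives a 4.1-fold lower number from compound 2 to compound 3 (0.62 log units; beyond the scatter) and so shows that the group at this position moves the number by itself, something the two earlier compounds could not show, since they differ in two places. The other single change, methoxy in place of chloro on an aromatic carbon, gives a 7.7-fold higher number from compound 1 to compound 3 (0.89 log units; beyond the scatter) and shows that this second place matters as well, so among these three compounds the chlorine-bearing group gives the lower number in each place, with no compound going against this. Nothing measured here tells why either step occurs.

On these data alone, the step from compound 2 to compound 3 swaps the substituent type and shifts its ring position at once, so 3,4-dichlorophenyl on the sulfonyl sulfur would be needed to separate the two, and it remains open which of them carries the drop. Also open, as far as these compounds go, is how far the number would move with other groups on the aromatic carbon that holds the methoxy or chloro, such as a fluoro, a nitrile or an amine.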